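The compounds below may be only part of what the source reports. "The series", "measured", "known", "first", "only" and "open" are said of these compounds alone.

Going by the values given here, in a functional assay on SK-BR-3 cells (Homo sapiens) for antiproliferative activity (a higher number here means a weaker inhibitor, a lower number a stronger inhibitor), compound 1 `CC(C)=CCc1cccc(C(=O)Nc2cc3ccc(OC4CCN(C)CC4)c(C)c3oc2=O)c1` gives 1680 nM and compound 2 `C=CCc1cc(C(=O)Nc2cc3ccc(OC4CCN(C)CC4)c(C)c3oc2=O)ccc1O` gives 2430 nM, so compound 2 stands level with the only other measured compound. Among the compounds with values here, the one measured step, a 1.4-fold higher number from compound 1 to compound 2 (0.16 log units; within the scatter), also altered this aromatic group and stayed within the scatter. Compound 3 `Cc1c(OC2CCN(C)CC2)ccc2cc(NC(=O)c3ccc(O)cc3)c(=O)oc12` differs from compound 2 by hydrogen in place of allyl on an aromatic carbon. Within the data shown here, no measured pair isolates this loss, so no step beyond the scatter is expected, and the estimated step is a 1.2-fold higher number from compound 2 to compound 3 (0.09 log units; within the scatter). Compound 3 is estimated at 3000 nM, within an expected range of 1100 nM to 9000 nM.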

Compound 3, half-maximal inhibitory concentration: 840 nM
For compound 3 the middle estimate is 3.6-fold (0.55 log units) above the measured one; the whole stated range lies above it.
By their numbers in this assay, from the lowest: compounds 3, 1 and 2 (each within the scatter of the next, the first and the last beyond it).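

Taking the allyl group off the aromatic carbon ortho to the hydroxy group gives a 2.9-fold lower number from compound 2 to compound 3 (0.46 log units; beyond the scatter) in this assay, the first step here beyond the scatter, so this position does bear on the read-out and allyl is not needed there. The other comparison, a 2.0-fold lower number from compound 1 to compound 3 (0.30 log units; within the scatter), separates the 4-hydroxyphenyl and 3-(3-methylbut-2-en-1-yl)phenyl groups by no more than the scatter. Nothing given here explains the step. The compounds shown leave open whether a methyl group at this position would read like hydrogen or like allyl. They also leave open what a methoxy group would do in place of the hydroxy group.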